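Trimming an Ethyl to a Methyl on an Inactive Sulfonamide

The source may hold more compounds than are shown below. What is called first, only, known or untested is meant among the compounds shown, and "the series" means these compounds.

Measured so far in an assay on isolated protein for inhibition of malate dehydrogenase, mitochondrial (Sus scrofa), with stated times of 45 min and 30 min; a higher number here means a weaker inhibitor, a lower number a stronger inhibitor:
compound 1 `CCc1ccc(S(=O)(=O)Nc2ccc(-c3nc4ccccc4o3)cc2)cc1` gives > 63000 nM, which is a limit of the assay rather than a number.
compound 2 `O=S(=O)(Nc1ccc2oc(-c3ccccc3)nc2c1)c1cccs1` gives > 63000 nM, again a limit of the assay rather than a number.

Compound 1 therefore cannot be placed above or below compound 2: both values sit at the limit of > 63000 nM in this assay, at which 2 of the 2 values shown sit, so nothing about order can be read from them. Among the measured compounds shown here, no pair of measured compounds differing in one place has been compared.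

Compound 3 `Cc1ccc(S(=O)(=O)Nc2ccc(-c3nc4ccccc4o3)cc2)cc1` differs from compound 1 by a single change, (hydrogen in place of methyl on a saturated chain carbon bound to an aromatic carbon). Since compound 1 stands at the limit, the step from compound 1 to compound 3 in this assay is expected to be none beyond the scatter, a step that the limit leaves unreadable from compound 1 to compound 3. Compound 3 is therefore estimated at 90000 nM, with a range from 30000 nM to 300000 nM, and most probably this assay will again report only a limit for compound 3.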

Compound 3, half-maximal inhibitory concentration: > 63000 nM
Compound 3: only a limit was reported (the forecaster's own chance of this, stated with the estimate: 85%); the middle value is on the limit's open side.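

Compound 3 gives > 63000 nM in this assay and this is a limit, not a number. Among the compounds shown here, compound 1 and compound 3 both stand at that limit, so no step between them can be read: the limit of > 63000 nM in this assay, at which 3 of the 3 values shown sit. The compounds shown leave open what, if anything, would give a measurable inhibition in this series.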